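A few compounds are considered here, and "the series" means these few. Any claim that something is new, unique, unknown or untested is made for them only; others in the source may bear on it.

For the measured compounds named here, in a functional assay on the whole organism (strain albino) with Mus musculus as the target, in the maximal electroshock model, with a stated time of 0.5 h (a higher number here means that more compound is needed for the effect, a lower number that less compound is needed), compound 1 `O=C1c2ccccc2C(=O)N1c1ccccc1` gives 66.2 mg/kg, the lowest of the two actual numbers so far. Compound 2 `O=C1c2ccccc2C(=O)N1c1ccccc1Cl` gives 168 mg/kg. Compound 3 `O=C1c2ccccc2C(=O)N1c1ccc(F)cc1` reaches only a limit of the assay, > 300 mg/kg.

The next compound to be tested, compound 4 `O=C1c2ccccc2C(=O)N1c1cccc([N+](=O)[O-])c1`, carries nitro in place of hydrogen on an aromatic carbon, meta to a large group: nitro in place of hydrogen on an aromatic carbon. The closest guides are two other replacements of hydrogen on an aromatic carbon. Chloro gave a 2.5-fold higher number from compound 1 to compound 2 (0.40 log units; beyond the scatter), and fluoro gave an at least 4.5-fold higher number from compound 1 to compound 3 (0.65 log units; beyond the scatter). Neither of these groups is nitro, so the two steps guide only loosely, but both point to a higher number, meaning that more compound is needed. A modest rise is therefore expected here as well, estimated as a 2.1-fold higher number from compound 1 to compound 4 (0.33 log units; beyond the scatter). For compound 4 the estimated value is 140 mg/kg, with an expected range from 55 mg/kg to 350 mg/kg.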

Compound 4, dose for half-maximal effect: 174 mg/kg
Compound 4: the middle estimate sits 1.2-fold (0.09 log units) below what was measured; the measured number falls inside the stated range.
By their numbers in this assay, from the lowest: compound 1; then compounds 2 and 4 (each within the scatter of the next). At a limit, above all of these: compound 3.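

Compound 4 is the first compound shown with a group meta to a large group, and in this assay nitro there gives a 2.6-fold higher number from compound 1 to compound 4 (0.42 log units; beyond the scatter). A group of 3 heavy atoms at this place thus raises the dose needed, yet the compound still gives a real number rather than a limit, and all three replacements of hydrogen on this ring now point the same way, with none going against. Nothing in the data at hand accounts for this rise.

With only one group at this place, the compounds shown cannot separate the effect of nitro itself from the effect of the position. From the compounds shown here alone, it remains open whether an amine or a carboxylic acid at this place, or nitro on another carbon of the ring, would give a similar rise.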